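Carboxy for methoxy in a cytotoxicity series

This account rests on a few compounds, and the source may have more. Where it says the series, first, only, none or still open, it means among the compounds named here.

Compound 1 `O=C(O)c1ccc(-c2ccc(Cl)cc2COc2ccc(-c3nc4cc(C(=O)O)ccc4n3C3CCCCC3)cc2)cc1`: > 50000 nM (a limit)
Compound 2 `COc1ccc(-c2ccc(Cl)cc2)c(COc2ccc(-c3nc4cc(C(=O)O)ccc4n3C3CCCCC3)cc2)c1`: 24000 nM
Compound 3 `O=C(O)c1ccc(-c2ccc(Cl)cc2)c(COc2ccc(-c3nc4cc(C(=O)O)ccc4n3C3CCCCC3)cc2)c1`: not yet measured

Going by the values given here, in a functional assay on Huh-5-2 cells (Homo sapiens), read by MTT assay (a lower number here means that less compound is tolerated, a higher number that more compound is tolerated), compound 2 gives 24000 nM, the only actual number so far. Compound 1 gives > 50000 nM, which is a limit and not a number.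

Compound 3 differs from compound 2 by carboxy in place of methoxy on an aromatic carbon, meta to a large group and para to a 4-chlorophenyl group (carboxy in place of methoxy on an aromatic carbon). No measured one-place change is available to size this step. Compound 1, which also carries a carboxy group outside the shared core, reports only the limit > 50000 nM, so a rise in this assay is expected, of about the usual scatter. The expected change is a 1.9-fold higher number from compound 2 to compound 3 (0.27 log units; within the scatter). For compound 3 the estimated value is 45000 nM, with an expected range from 22000 nM to 90000 nM.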

Compound 3, half-maximal cytotoxic concentration: > 50000 nM
Compound 3: only a limit was reported (the forecaster's own chance of this, stated with the estimate: 55%); at least 1.1-fold (0.04 log units) between middle value and limit.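

In this assay, carboxy in place of methoxy on an aromatic carbon, meta to a large group and para to a 4-chlorophenyl group, gives an at least 2.0-fold higher number from compound 2 to compound 3 (0.31 log units; beyond the scatter). Going by these compounds alone, this is the first one-place change that can be sized, and it shows that this position can move the number beyond the scatter. Compound 3 gives > 50000 nM, which is a limit and not a number, so the step fixes only a floor, and the reading stops short of its full size because of where the assay ends: the limit of > 50000 nM in this assay, at which 2 of the 3 values shown sit.

On these data alone, how far the true value of compound 3 lies past that limit remains open. So does whether a hydroxy group, an amine or a primary amide at this position would raise the number in the same way.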